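The source may hold more compounds than are shown below. What is called first, only, known or untested is meant among the compounds shown, and "the series" means these compounds.

Measured in an assay on isolated protein for inhibition of Fatty-acid amide hydrolase 1 (Rattus norvegicus), read by fluorescence; on this read-out higher numbers stand for weaker inhibition and lower numbers for stronger inhibition:
compound 1 `N#Cc1cccc(OC(=O)N2CCC(S(=O)(=O)C(c3ccccc3)c3ccccc3)CC2)c1`: "not determined" (no result reported)
compound 2 `N#Cc1cc(O)cc(OC(=O)N2CCC(C(c3ccccc3)c3ccccc3)CC2)c1`: > 1000 nM
compound 3 `N#Cc1cccc(OC(=O)N2CCC(C(c3ccccc3)c3ccccc3)CC2)c1`: > 1000 nM

In this assay compound 2 gives only a limit, > 1000 nM, not a number. Compound 3 likewise gives only a limit, > 1000 nM. Compound 1 has no result in this assay. For the measured compounds named here, both recorded values thus sit at the limit of > 1000 nM in this assay, at which 2 of the 3 values shown sit, and the single step between measured compounds, a step that the two limits leave unreadable from compound 2 to compound 3, hydrogen in place of hydroxy on an aromatic carbon, cannot be sized from the two limits.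

Compound 4 `N#Cc1cccc(OC(=O)N2CCC(C(c3ccccc3)c3ccccc3)CC2)n1` differs from compound 2 by 6-cyanopyridin-2-yl in place of 3-cyano-5-hydroxyphenyl on an oxygen next to a carbonyl group. Going by the values given here, no measured step bears on this change: the only step recorded, from compound 2 to compound 3, is unreadable and alters the ring in a different way. The expectation for compound 4 in this assay can therefore rest only on where compound 2 stands, and the estimated step that the limit leaves unreadable from compound 2 to compound 4 is set near nothing, with a wide range in either direction. Compound 4 is accordingly estimated at 1500 nM, expected to lie between 200 nM and 10000 nM, with a fair chance that it too is reported only as a limit.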

Compound 4, half-maximal inhibitory concentration: > 1000 nM
Compound 4: only a limit was reported (the forecaster's own chance of this, stated with the estimate: 60%); the middle value is on the limit's open side.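

Compound 4 gives > 1000 nM, which is a limit and not a number. The steps to compound 4 from compound 2 and compound 3 therefore cannot be read, since each joins two limits: the limit of > 1000 nM in this assay, at which 3 of the 4 values shown sit.

The compounds shown leave open how strongly compound 2, compound 3 and compound 4 each inhibit the enzyme, and whether these ring changes shift that inhibition at all.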